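This account rests on a few compounds, and the source may have more. Where it says the series, first, only, none or still open, it means among the compounds named here.

Measured so far:
compound 1 `COc1cccc(-c2nn3cc(-c4cccc(N)c4)nc3s2)c1` gives 230000 nM
compound 2 `Nc1cccc(-c2cn3nc(Cc4ccc(Cl)cc4)sc3n2)c1` gives 25000 nM
compound 3 `C=C(Br)C(=O)Nc1cccc(-c2cn3nc(Cc4ccc(Cl)cc4)sc3n2)c1` gives 2700 nM

In a functional assay on HeLa cells (Homo sapiens) for inhibition, read by cell counting, with a stated time of 4 days (on this read-out lower numbers stand for stronger inhibition and higher numbers for weaker inhibition), compound 2 stands second highest of the three numbers: compound 1 sits far higher, while compound 3 sits far lower. Compound 4 `Nc1cccc(-c2cn3nc(CCc4ccccc4)sc3n2)c1` differs from compound 2 by benzyl in place of 4-chlorophenyl on a saturated chain carbon bound to an aromatic carbon. Within the data shown here, the only measured step here, a 9.3-fold lower number from compound 2 to compound 3 (0.97 log units; beyond the scatter), alters a different place, the amino nitrogen, so no measured step bears on the present change. With no guidance, the expectation is a step no larger than the scatter, leaning slightly to a higher number. Compound 4 is therefore estimated at 35000 nM, with a range from 12000 nM to 100000 nM, which is an expected step of a 1.4-fold higher number from compound 2 to compound 4 (0.15 log units; within the scatter).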

Compound 4, half-maximal inhibitory concentration: 242000 nM
Compound 4: the middle estimate sits 6.9-fold (0.84 log units) below what was measured, and the stated range ends below it.
By their numbers in this assay, from the lowest: compound 3; then compound 2; then compounds 1 and 4 (each within the scatter of the next).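

This position responds to change: in this assay, benzyl in place of 4-chlorophenyl gives a 9.7-fold higher number from compound 2 to compound 4 (0.99 log units; beyond the scatter), even though both groups hold 7 heavy atoms and one six-membered aromatic ring. The swap removes the chlorine and adds a carbon to the chain in a single step, so the two changes cannot be told apart here. No measurement shown here explains the step. Still open, from the compounds shown here alone, is how phenyl on the same saturated chain carbon would compare. Also open, going by these compounds, is whether 4-chlorophenyl on a longer chain would hold the value of compound 2, 25000 nM.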